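From 4-methylpiperazin-1-yl to 4-ethylpiperazin-1-yl

The compounds below may be only part of what the source reports. "The series", "measured", "known", "first", "only" and "open" are said of these compounds alone.

In an ADME assay on Vero cells (Chlorocebus sabaeus) for cytotoxicity, read by neutral red uptake, with a stated time of 48 h (on this read-out lower numbers stand for stronger inhibition and higher numbers for weaker inhibition), compound 1 `Clc1ccc2c(NCCCn3cnc4c(N5CCCCC5)nc(Cl)nc43)ccnc2c1` gives > 10400 nM, which is a limit. Compound 2 `CN1CCN(c2nc(Cl)nc3c2ncn3CCCNc2ccnc3cc(Cl)ccc23)CC1` gives > 10100 nM, likewise a limit and not a number. Compound 3 `CCN1CCN(c2nc(Cl)nc3c2ncn3CCCNc2ccnc3cc(Cl)ccc23)CC1` differs from compound 2 by methyl in place of hydrogen on a saturated chain carbon bound to an amine nitrogen in a ring, turning methyl into ethyl. Going by the values given here, the only measured step that bears on this, a step that the two limits leave unreadable from compound 1 to compound 2, offers no size to carry over. In this assay the expected outcome is therefore no change beyond the scatter, estimated as a number no higher from compound 2 to compound 3 (the limit leaves the size open). For compound 3 the estimated value is 10000 nM, with an expected range from 4000 nM to 20000 nM.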

Compound 3, half-maximal inhibitory concentration: > 9830 nM
Compound 3 gave a limit, no number; the forecaster's own chance of this, stated with the estimate: 75%; the middle value does not contradict the limit.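

In this assay compound 3 gives > 9830 nM, a limit and not a number. Going by these compounds alone, compound 1 and compound 2 also stand at limits, so no step among the three can be read. On these data alone, what stays open is the actual cytotoxic concentration of each compound.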